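From bromomethyl ketone to epoxide: stability in neutral buffer

The source may hold more compounds than are shown below. What is called first, only, known or untested is meant among the compounds shown, and "the series" means these compounds.

Compound 1 `C=CC(=O)Oc1cc(C(F)(F)F)cc(C(F)(F)F)c1` and compound 2 `O=C(CBr)c1cc(C(F)(F)F)cc(C(F)(F)F)c1` share a core carrying two trifluoromethyl groups. In an ADME assay for pharmacokinetics, read by LC-MS, in phosphate buffer, with a stated time of 72 h, at pH 7.4, tested at 250 uM (a lower number here means that the compound disappears faster, a higher number that the compound lasts longer), compound 1 gives only a limit, < 0.017 h. In this assay compound 2 likewise gives only a limit, < 0.017 h. The step that the two limits leave unreadable from compound 1 to compound 2 cannot be read because both values sit at the limit of < 0.017 h in this assay, at which 2 of the 2 values shown sit. Compound 3 `FC(F)(F)c1cc(C2CO2)cc(C(F)(F)F)c1` differs from compound 2 by oxiran-2-yl in place of (bromomethyl)carbonyl on an aromatic carbon. For the measured compounds named here, no measured step reaches this change, so the expectation rests on the structures alone. Compound 3 is expected to last longer, an estimated 10 h, between 0.5 h and 100 h, a step of an at least 580-fold higher number from compound 2 to compound 3 (2.76 log units; beyond the scatter).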

Compound 3, half-life: > 50 h
Compound 3 ended at the assay's limit (the forecaster's own chance of this, stated with the estimate: 30%); middle value at least 5.0-fold (0.69 log units) away from the limit.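

In this assay this place on the shared core proves able to change the outcome: the earlier step could not be read, whereas oxiran-2-yl gives an at least 2900-fold higher number from compound 2 to compound 3 (3.46 log units; beyond the scatter) and, set against (vinylcarbonyl)oxy, an at least 2900-fold higher number from compound 1 to compound 3 (3.46 log units; beyond the scatter) in the same direction. On these data alone, both steps are therefore large, yet their true size stays unknown. The value of compound 3 is a limit, not a number: the limit of > 50 h in this assay, at which 1 of the 3 values shown sits.

As far as these compounds go, how long compound 3 actually lasts remains open. So does how an amine or a carboxylic acid at this place would fare.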